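The source may hold more compounds than are shown below. What is called first, only, known or untested is meant among the compounds shown, and "the series" means these compounds.

Going by the values given here, in a physicochemical assay for solubility (a higher number here means a more soluble compound, a lower number a less soluble compound), compound 1 `Cn1nccc1-c1cc(C(F)(F)F)ccc1[C@H]1CCOc2cc(S(=O)(=O)Nc3cnccn3)ccc21` gives 1170000 nM and is the higher of the two compounds measured so far. Compound 2 `O=S(=O)(Nc1nccs1)c1ccc2c(c1)OCC[C@@H]2c1ccc(C(F)(F)F)cc1-c1ccc(F)cn1` gives 7000 nM and sits far lower, a gap well beyond the usual scatter. However, no two measured compounds differ in one place only, so no measured step speaks directly to the change considered here.

Compound 3 `Cn1nccc1-c1cc(C(F)(F)F)ccc1[C@H]1CCOc2cc(S(=O)(=O)Nc3ccncn3)ccc21` has the same atoms as compound 1, joined differently, with pyrimidin-4-yl in place of pyrazin-2-yl on a sulfonamide nitrogen. Among the compounds with values here, with no measured precedent for this swap, the expectation is a slight fall at most, with no change beyond the scatter, and the estimated step is a 1.5-fold lower number from compound 1 to compound 3 (0.17 log units; within the scatter) in size and direction. Compound 3 is expected to give 800000 nM in this assay (estimated range 200000 nM to 2000000 nM).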

Compound 3, solubility: 1180000 nM
For compound 3 the middle estimate is 1.5-fold (0.17 log units) below the measured one, and the stated range covers the measured number.
By their numbers in this assay, from the lowest: compound 2; then compounds 1 and 3 (each within the scatter of the next).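

In this assay, moving one ring nitrogen so that pyrimidin-4-yl stands in place of pyrazin-2-yl on a sulfonamide nitrogen gives a 1.0-fold higher number from compound 1 to compound 3 (0.00 log units; within the scatter). Going by these compounds alone, this is the first direct reading at this position: on the core of compound 1, these two rings, built from the same atoms, are not told apart by this read-out. Nothing measured here bears on the reason for this result.

From the compounds shown here alone, it remains open whether a ring with a different count of nitrogens, such as pyridin-2-yl or a plain phenyl, would also leave the number in place, and whether the same swap would behave alike on another core. Compound 2 differs from compound 1 and compound 3 in more than one place, so its much lower number cannot be pinned on any single group.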